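Cyanoethenyl in place of hydroxymethyl: notes on the series

The compounds below may be only part of what the source reports. "The series", "measured", "known", "first", "only" and "open" are said of these compounds alone.

compound 1 (`C=C[C@@](C)(/C=C/c1ccc(O)cc1)CC/C=C/C(=O)c1ccccc1`): > 26000 nM
compound 2 (`C=C[C@@](C)(/C=C/c1ccc(O)cc1)CC/C=C(\C)C=O`): > 26000 nM
compound 3 (`C=C[C@@](C)(/C=C/c1ccc(O)c(CO)c1)CCC=C(C)C`): > 26000 nM

All three entries come from a functional assay on Raji cells (Homo sapiens) for cytotoxicity, with a stated time of 72 h (a higher number here means that more compound is needed for the effect, a lower number that less compound is needed), and none of them is a number. Compound 3 gives > 26000 nM and this is a limit. Among the compounds with values here, the series so far shows only the limit of > 26000 nM in this assay, at which 3 of the 3 values shown sit, and offers no step between measured compounds.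

Compound 4 (`C=C[C@@](C)(/C=C/c1ccc(O)c(/C=C/C#N)c1)CCC=C(C)C`) carries 2-cyanoethenyl in place of the hydroxymethyl of compound 3 on an aromatic carbon (2-cyanoethenyl in place of hydroxymethyl on an aromatic carbon). In this assay a small step towards less compound needed is expected, or none beyond the scatter, and a further limit is quite possible. The expected change is an at least 1.3-fold lower number from compound 3 to compound 4 (0.11 log units; that floor lies within the scatter) as an estimate only. Compound 4 is expected at 20000 nM with an estimated range of 8000 nM to 26000 nM in this read-out.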

Compound 4, half-maximal effective concentration: > 26000 nM
Compound 4 ended at the assay's limit; the forecaster's own chance of this, stated with the estimate: 55%; at least 1.3-fold (0.11 log units) between middle value and limit.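

No step can be read from compound 3 to compound 4, since both entries are limits and not numbers: the limit of > 26000 nM in this assay, at which 4 of the 4 values shown sit.

What 2-cyanoethenyl in place of hydroxymethyl does to the read-out stays open, and no compound shown gives a number short of the limit.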